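Five-ring substituent and cytotoxicity: methoxymethyl to trifluoromethyl

This account rests on a few compounds, and the source may have more. Where it says the series, first, only, none or still open, it means among the compounds named here.

Measured compounds:
compound 1 `CNC(=O)c1cc(Oc2ccc(-c3noc(C)n3)cc2)ccn1`: > 100000 nM
compound 2 `CNC(=O)c1cc(Oc2ccc(-c3noc(C(C)C)n3)cc2)ccn1`: 16100 nM
compound 3 `CNC(=O)c1cc(Oc2ccc(-c3noc(COC)n3)cc2)ccn1`: 63400 nM

In an ADME assay on H1-HeLa cells (Homo sapiens) for cytotoxicity, read by MTT assay, with a stated time of 3 days (on this read-out lower numbers stand for higher toxicity in this test and higher numbers for lower toxicity in this test), compound 1 gives > 100000 nM, which is a limit of the assay rather than a number (the limit of > 100000 nM in this assay, at which 1 of the 3 values shown sits). Compound 2 gives 16100 nM in this assay, and compound 3 gives 63400 nM. Of the two numbers shown, compound 3 stands highest; its nearest neighbour is compound 2, separated by a 3.9-fold higher number from compound 2 to compound 3 (0.60 log units; beyond the scatter).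

Compound 4 `CNC(=O)c1cc(Oc2ccc(-c3noc(C(F)(F)F)n3)cc2)ccn1` differs from compound 3 by trifluoromethyl in place of methoxymethyl on an aromatic carbon. Two measured steps at this same aromatic carbon bear on the change: an at least 6.2-fold lower number from compound 1 to compound 2 (0.79 log units; beyond the scatter) and a 3.9-fold higher number from compound 2 to compound 3 (0.60 log units; beyond the scatter), each a modest shift, while an at least 1.5-fold lower number from compound 1 to compound 3 (0.19 log units; that floor lies within the scatter) sits at a floor within the scatter. Exchanging one small substituent for another at this position has so far moved the read-out by modest amounts in either direction, and for compound 4 a modest step toward a lower number is expected, a 2.1-fold lower number from compound 3 to compound 4 (0.32 log units; beyond the scatter). The estimate for compound 4 in this assay is 30000 nM, expected to fall between 10000 nM and 100000 nM.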

Compound 4, half-maximal cytotoxic concentration: 35000 nM
Compound 4: the middle estimate sits 1.2-fold (0.07 log units) below what was measured, within the range that was stated.
By their numbers in this assay, from the lowest: compound 2; then compounds 4 and 3 (each within the scatter of the next). At a limit, above all of these: compound 1.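

In this assay, the two substituents at this aromatic carbon next to the ring oxygen cannot be told apart, with a 1.8-fold lower number from compound 3 to compound 4 (0.26 log units; within the scatter). Trifluoromethyl does separate from isopropyl, with a 2.2-fold higher number from compound 2 to compound 4 (0.34 log units; beyond the scatter), so isopropyl alone stays clearly at the low end among the numbers shown, and an at least 2.8-fold lower number from compound 1 to compound 4 (0.45 log units; beyond the scatter) also places compound 4 clear of the methyl compound. That last step is only a floor, since compound 1 stands at a limit of the assay and not at a number: the limit of > 100000 nM in this assay, at which 1 of the 4 values shown sits.

The compounds shown leave open how an amine, a carboxylic acid or a longer chain such as butyl would read at this carbon. They also leave open whether a cyclopropyl group would track isopropyl, the one substituent here that gives the lowest number.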